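A chlorophenyl swap on compound 3

A few compounds are considered here, and "the series" means these few. Any claim that something is new, unique, unknown or untested is made for them only; others in the source may bear on it.

Compound 1 (`C[C@H]1CC[C@@H]2[C@@H](OC(=O)[C@]23CC(c2ccc(C#N)cc2)N(c2ccccc2)O3)[C@]2(C)C(=O)C=C[C@@]12O`), compound 2 (`Cc1ccc(C2C[C@@]3(ON2c2ccccc2)C(=O)O[C@@H]2[C@H]3CC[C@H](C)[C@]3(O)C=CC(=O)[C@@]23C)cc1`) and compound 3 (`C[C@H]1CC[C@@H]2[C@@H](OC(=O)[C@]23CC(c2cccc(F)c2)N(c2ccccc2)O3)[C@]2(C)C(=O)C=C[C@@]12O`) share one core and differ in the substituted phenyl group on it. In a physicochemical assay for lipophilicity (on this read-out higher numbers stand for higher lipophilicity and lower numbers for lower lipophilicity), compound 1 gives 2.94 and compound 2 gives 3.64 while compound 3 gives 3.35 as its reading. That places compound 3 within the scatter of compound 2 and clearly above compound 1.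

Compound 4 (`C[C@H]1CC[C@@H]2[C@@H](OC(=O)[C@]23CC(c2ccccc2Cl)N(c2ccccc2)O3)[C@]2(C)C(=O)C=C[C@@]12O`) carries 2-chlorophenyl in place of 3-fluorophenyl on a saturated ring carbon. The steps away from the nitrile of compound 1 were modest (a number 0.70 log units higher from compound 1 to compound 2 (beyond the scatter) and a number 0.41 log units higher from compound 1 to compound 3 (beyond the scatter)). Neither compound 3 nor compound 4 carries a nitrile, which makes the remaining step the closest guide (a number 0.29 log units lower from compound 2 to compound 3 (within the scatter)), and it stayed within the scatter. In this assay only a small upward move is therefore expected (a number 0.25 log units higher from compound 3 to compound 4 (within the scatter)), not a clear step beyond the scatter. The expected value for compound 4 is 3.6 within an estimated range of 3.2 to 4 around it.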

Compound 4, partition coefficient: 3.87
Beside the measured number, compound 4's estimate is 0.27 log units below it; the measured number falls inside the stated range.
By their numbers in this assay, from the lowest: compound 1; then compounds 3, 2 and 4 (each within the scatter of the next, the first and the last beyond it).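

Swapping 3-fluorophenyl for 2-chlorophenyl on this saturated ring carbon gives the first step beyond the scatter between two compounds without a nitrile in this assay (a number 0.52 log units higher from compound 3 to compound 4 (beyond the scatter)). Compound 4 still sits within the scatter of the compound carrying 4-methylphenyl (a number 0.23 log units higher from compound 2 to compound 4 (within the scatter)), while the step from the compound carrying 4-cyanophenyl is the largest printed for this position (a number 0.93 log units higher from compound 1 to compound 4 (beyond the scatter)). Nothing available explains why these substituted phenyl groups read as they do.

This swap changes both the halogen and its place on the phenyl ring, so the compounds shown cannot separate those two changes; 3-chlorophenyl or 2-fluorophenyl would pull them apart. From the compounds shown here alone, how a phenyl group bearing an amine or a carboxylic acid would read at this position also remains open.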